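The source may report more compounds than this note shows. Statements on the series, on what has been measured and on what is new or still open speak of the compounds shown alone.

Compound 1 `C/C=C1/[C@H](O[C@@H]2O[C@H](COC(C)=O)[C@@H](OC(C)=O)[C@H](OC(C)=O)[C@H]2OC(C)=O)OC=C(C(=O)OC)[C@H]1CC(=O)OCCCCCCCCCCCCCCC`: in a functional assay on HCT-116 cells (Homo sapiens) for antiproliferative activity, read by MTT assay, with a stated time of 72 h (on this read-out lower numbers stand for stronger inhibition and higher numbers for weaker inhibition), compound 1 gives 21000 nM.
Compound 2 `C/C=C1/[C@H](O[C@@H]2O[C@H](CO)[C@@H](O)[C@H](O)[C@H]2O)OC=C(C(=O)OC)[C@H]1CC(=O)OCCC1CCCCC1`: in this assay compound 2 gives 13700 nM.
Compound 3 `C/C=C1/[C@H](O[C@@H]2O[C@H](CO)[C@@H](O)[C@H](O)[C@H]2O)OC=C(C(=O)O)[C@H]1CC(=O)O`: in this assay compound 3 gives > 50000 nM, which is a limit of the assay and not a number; this is the limit of > 50000 nM in this assay, at which 1 of the 3 values shown sits.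

Among the two numbers that were obtained, compound 2 holds the lower one. Compound 1 stands nearest to it, and the gap between compound 1 and compound 2 lies within the usual scatter of the assay, so the two cannot be ranked against each other. Compound 3 shares the glycoside and the core of compound 2 but carries a free acid in place of both esters.

The next compound, compound 4 `C/C=C1/[C@H](O[C@@H]2O[C@H](CO)[C@@H](O)[C@H](O)[C@H]2O)OC=C(C(=O)OC)[C@H]1CC(=O)OCCc1ccc(O)c(O)c1`, has not yet been measured in this assay. Its difference from compound 2 is this: 3,4-dihydroxyphenyl in place of cyclohexyl on a saturated chain carbon, two bonds along the chain from an oxygen next to a carbonyl group. Within the data shown here, none of the measured pairs differs in one place, so no measured step speaks directly to this exchange; the only guide is that compound 1 and compound 2, with quite different ester chains, sit close together.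

On that basis compound 4 is expected to remain near compound 2, with a step of a 1.0-fold higher number from compound 2 to compound 4 (0.01 log units; within the scatter) that is not expected to go beyond the scatter. Compound 4 is therefore estimated to give 14000 nM in this assay, most likely between 4000 nM and 45000 nM.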

Compound 4, half-maximal inhibitory concentration: 182000 nM
Compound 4: middle estimate off by 13-fold (1.11 log units), on the low side; measured number outside the range, above it.
By their numbers in this assay, from the lowest: compounds 2 and 1 (each within the scatter of the next); then compound 4.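

The end of this ester chain is not indifferent to what it carries: 3,4-dihydroxyphenyl in place of cyclohexyl on a saturated chain carbon, two bonds along the chain from an oxygen next to a carbonyl group, gives a 13-fold higher number from compound 2 to compound 4 (1.12 log units; beyond the scatter) in this assay. Among these compounds, this is the first exchange made in one place only, and it is a large one. Compound 1 and compound 2 gave no sign of such a sensitivity, but they differ in more than one place, so their closeness said little about this position on its own.

A single exchange cannot separate the part played by the aromatic ring from that of its two hydroxyl groups, and a plain phenyl group or a 4-hydroxyphenyl group on the same chain is not among the compounds shown, so it stays open which of the two carries the step. Compound 3 is recorded only as a limit of the assay and not as a number, and it differs from the others in more than one place, so it does not help to settle this: the limit of > 50000 nM in this assay, at which 1 of the 4 values shown sits.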